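A few compounds are considered here, and "the series" means these few. Any claim that something is new, unique, unknown or untested is made for them only; others in the source may bear on it.

Of the compounds shown here, three built on one shared core have been tested in an ADME assay on CEM-SS cells (Homo sapiens) for cytotoxicity, read by XTT assay, with a stated time of 6 days; on this read-out higher numbers stand for lower toxicity in this test and lower numbers for higher toxicity in this test. Compound 1, `CCCC(=O)OCSc1ccccc1C(=O)NCC(N)=O`, reaches only the limit of the assay: in this assay compound 1 gives > 100 uM, a limit and not a number. Compound 2, `CCCC(=O)OCSc1ccccc1C(=O)NCCCCNC(C)=O`, gives 17.4 uM in this assay. Compound 3, `CCCC(=O)OCSc1ccccc1C(=O)NCC(=O)NC`, also stops at the limit: in this assay compound 3 gives > 100 uM. Compound 3 thus stands with compound 1 at the limit of > 100 uM in this assay, at which 2 of the 3 values shown sit, while compound 2 alone gives a read number. The step of an at least 5.7-fold lower number from compound 1 to compound 2 (0.75 log units; beyond the scatter) and the step of an at least 5.7-fold higher number from compound 2 to compound 3 (0.75 log units; beyond the scatter) both set compound 2 apart from the two limit values, whereas the step that the two limits leave unreadable from compound 1 to compound 3 cannot be sized, as both ends are limits.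

Compound 4, `CCCC(=O)OCSc1ccccc1C(=O)NCC(=O)NCC(N)=O`, differs from compound 3 in one place: carbamoyl in place of hydrogen on a saturated chain carbon bound to an amide-type nitrogen. Read one bond further out, methylcarbamoyl becomes (carbamoylmethyl)carbamoyl, so compound 4 carries a carbamoyl like compound 1 and a methylcarbamoyl like compound 3, and both of those compounds sit at the limit. Within the data shown here, no measured step is of the same kind; the closest, from compound 1 to compound 3, is unreadable. Compound 4 is therefore expected to remain at the limit, with a step that the limit leaves unreadable from compound 3 to compound 4 that is within the scatter. The estimate for compound 4 is 150 uM, within 60 uM to 400 uM.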

Compound 4, half-maximal toxic concentration: > 100 uM
Compound 4 was reported as a limit; the forecaster's own chance of this, stated with the estimate: 80%; the middle value does not contradict the limit.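

Adding carbamoyl on a saturated chain carbon bound to an amide-type nitrogen leaves compound 4 at a limit of this assay and not at a number, so this longer group behaves here as the shorter ones of compound 1 and compound 3 do: the limit of > 100 uM in this assay, at which 3 of the 4 values shown sit. The steps from compound 1 and from compound 3 to this compound cannot be read, as both ends of each are limits. Setting (carbamoylmethyl)carbamoyl in place of 3-acetamidopropyl gives an at least 5.7-fold higher number from compound 2 to compound 4 (0.75 log units; beyond the scatter), so a third group at this place now stands apart from the 3-acetamidopropyl chain, which remains the only group shown with a read number.

Going by these compounds, how compound 1, compound 3 and compound 4 rank among themselves stays open, as none of the three has a read number in this assay. Also open, on these data alone, is whether a primary amine or a carboxylic acid at the end of the chain, or a longer plain alkyl chain, would bring a read number as the 3-acetamidopropyl group of compound 2 does.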